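Carbamoyl in place of chloro on the urea aryl ring

The compounds below may be only part of what the source reports. "The series", "measured", "known", "first", "only" and "open" are said of these compounds alone.

Measured compounds:
- compound 1, `Cc1cc(NC(=O)Nc2ccc(C(=O)O)cc2)c2ccccc2n1`, in an ADME assay on HEK293 cells (Homo sapiens) for cytotoxicity, with a stated time of 72 h (a higher number here means that more compound is needed for the effect, a lower number that less compound is needed), gives > 25000 nM, which is a limit of the assay.
- compound 2, `Cc1cc(NC(=O)Nc2ccc(F)cc2)c2ccccc2n1`, gives > 25000 nM, also a limit.
- compound 3, `Cc1cc(NC(=O)Nc2ccc(Cl)cc2)c2ccccc2n1`, gives > 25000 nM, again a limit.

Compound 3 therefore stands at the same limit as the other two, with no number to place it above or below them, and the limit of > 25000 nM in this assay, at which 3 of the 3 values shown sit, sums this up. The measured steps are all unreadable for the same reason: a step that the two limits leave unreadable from compound 1 to compound 2, a step that the two limits leave unreadable from compound 1 to compound 3 and a step that the two limits leave unreadable from compound 2 to compound 3.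

Compound 4, `Cc1cc(NC(=O)Nc2ccc(C(N)=O)cc2)c2ccccc2n1`, has not been measured. It differs from compound 3 as carbamoyl in place of chloro on an aromatic carbon. Among the measured compounds shown here, none of the measured steps gives a readable size, so no direction can be expected for a step that the limit leaves unreadable from compound 3 to compound 4, and a step beyond the scatter is not indicated. Compound 4 is estimated at 30000 nM, within 15000 nM to 100000 nM, with a limit again the most likely outcome.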

Compound 4, half-maximal effective concentration: > 25000 nM
Compound 4: only a limit was reported; the forecaster's own chance of this, stated with the estimate: 80%; the middle value lies beyond the limit too.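

The result for compound 4 is again a limit of the assay, so no step between it and compound 1, compound 2 or compound 3 can be read: the limit of > 25000 nM in this assay, at which 4 of the 4 values shown sit.

From the compounds shown here alone, how these four compounds would rank in this assay, and whether the change of group on the urea aryl ring alters the effect at all, stays open.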